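Series notes: saturated versus aromatic chain terminus

The source may hold more compounds than are shown below. What is called first, only, known or untested is meant among the compounds shown, and "the series" means these compounds.

Compound 1 `Cc1ccccc1-c1nc(C(=O)Nc2cccc(C(=O)O)c2)c(CCC2CCCCC2)[nH]1` and compound 2 `Cc1ccccc1-c1nc(C(=O)Nc2cccc(C(=O)O)c2)c(CCc2ccccc2)[nH]1` share one core and differ only at the end of the two-carbon chain. In an assay with Gastrin/cholecystokinin type B receptor (Mus musculus) as the target, read by radioligand binding (on this read-out lower numbers stand for stronger inhibition and higher numbers for weaker inhibition), compound 1 gives 617 nM, and in this assay compound 2 gives 2690 nM. Going by the values given here, the one step that is measured, a 4.4-fold higher number from compound 1 to compound 2 (0.64 log units; beyond the scatter), is modest but beyond the scatter. Among the compounds with values here, on these two numbers compound 2 stands as the higher of the pair, with compound 1 as its only neighbour.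

Compound 3 `Cc1ccccc1-c1nc(C(=O)Nc2cccc(C(=O)O)c2)c(CCC(C)(C)C)[nH]1` is not yet measured. It differs from compound 2 as follows: tert-butyl in place of phenyl on a saturated chain carbon, two bonds along the chain from an aromatic carbon. The entering tert-butyl has no ring, which puts it nearer to the cyclohexyl of compound 1 than to the phenyl of compound 2, so the step of a 4.4-fold higher number from compound 1 to compound 2 (0.64 log units; beyond the scatter) is the only one that bears on it, and it runs in the opposite sense to the change now made. A lower number is therefore expected for compound 3 in this assay, but smaller than the return to compound 1, since tert-butyl is also counted as fewer heavy atoms than cyclohexyl; the expected step is a 2.4-fold lower number from compound 2 to compound 3 (0.39 log units; beyond the scatter). The estimate for compound 3 in this assay is 1100 nM, with a range from 350 nM to 3500 nM.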

Compound 3, inhibition constant: 3800 nM
For compound 3 the middle estimate is 3.5-fold (0.54 log units) below the measured one, outside the stated range (above it).
By their numbers in this assay, from the lowest: compound 1; then compounds 2 and 3 (each within the scatter of the next).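

Working notes on the chain terminus: in this assay, tert-butyl in place of phenyl gives a 1.4-fold higher number from compound 2 to compound 3 (0.15 log units; within the scatter), so the aromatic ring of compound 2 and the ring-free group of compound 3 cannot be told apart on this read-out at this position. Tert-butyl in place of cyclohexyl gives a 6.2-fold higher number from compound 1 to compound 3 (0.79 log units; beyond the scatter), so among the three termini only the cyclohexyl of compound 1 stands apart, and a simple reading of saturated against aromatic no longer holds, with the saturated tert-butyl of compound 3 going against it. No evidence is at hand that accounts for this result.

On these data alone, it remains open whether the standing of compound 1 belongs to a saturated carbocycle in general, a question that cyclopentyl or cycloheptyl at the chain end would address, while piperidinyl would show what an amine in such a ring does. Also open, as far as these compounds go, is how a longer chain carrying the cyclohexyl would read in this assay, and whether the gap from tert-butyl to cyclohexyl persists there.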